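Pyridinyl ether on the chlorinated alcohol: expected cytotoxicity

A few compounds are considered here, and "the series" means these few. Any claim that something is new, unique, unknown or untested is made for them only; others in the source may bear on it.

Compound 1 `Fc1cccc(F)c1Cc1cnc(Nc2ccc(COc3ccncc3)cc2)o1` gives > 100000 nM, a limit of the assay.
Compound 2 `OCc1ccc(Nc2ncc(Cc3c(F)cccc3F)o2)cc1Cl` gives 90000 nM.
Compound 3 `OCc1ccc(Nc2ncc(Cc3c(F)cccc3F)o2)cc1` gives > 100000 nM, a limit of the assay.

All three were measured in an ADME assay on MT2 cells (Homo sapiens) for cytotoxicity, read by MTT assay; on this read-out lower numbers stand for higher toxicity in this test and higher numbers for lower toxicity in this test. The cores of compound 2 and compound 3 differ by chloro in place of hydrogen on an aromatic carbon. The step of an at least 1.1-fold higher number from compound 2 to compound 3 (0.04 log units; that floor lies within the scatter) is the only one that can be sized here, and its floor lies within the scatter. The change pyridin-4-yl in place of hydrogen on an oxygen on a saturated carbon gives the step that the two limits leave unreadable from compound 3 to compound 1, which cannot be read because of the limit of > 100000 nM in this assay, at which 2 of the 3 values shown sit.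

Compound 4 `Fc1cccc(F)c1Cc1cnc(Nc2ccc(COc3ccncc3)c(Cl)c2)o1` has not yet been measured. It carries the same change, (pyridin-4-yl in place of hydrogen on an oxygen on a saturated carbon), made this time on compound 2 rather than on compound 3. Compound 4 is expected to give about 100000 nM in this assay, with a plausible range from 50000 nM to 200000 nM. The expected step is a 1.1-fold higher number from compound 2 to compound 4 (0.05 log units; within the scatter). This expectation rests on compound 2, which gives 90000 nM. It also rests on the step that the two limits leave unreadable from compound 3 to compound 1, which cannot be sized. A limit rather than a number is a real possibility for compound 4.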

Compound 4, half-maximal cytotoxic concentration: 3800 nM
Compound 4: the middle estimate sits 26-fold (1.42 log units) above what was measured, outside the stated range (below it).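

In this assay, pyridin-4-yl in place of hydrogen on the oxygen of the chlorinated alcohol gives a 24-fold lower number from compound 2 to compound 4 (1.37 log units; beyond the scatter), so on this core the change moves the result well toward higher toxicity in this test. On the core without chloro, the same change cannot be read, and both compounds there give only a limit of the assay: the limit of > 100000 nM in this assay, at which 2 of the 4 values shown sit. Between the two pyridin-4-yl ethers, chloro in place of hydrogen gives an at least 26-fold lower number from compound 1 to compound 4 (1.42 log units; beyond the scatter), yet this does not establish that the chloro and pyridin-4-yl groups act together, and the comparison with the alcohol pair remains unsettled: the same change on two cores in this assay, an at least 1.1-fold higher number (0.04 log units; that floor lies within the scatter) from compound 2 to compound 3 and an at least 26-fold higher number (1.42 log units; beyond the scatter) from compound 4 to compound 1; the limit leaves it open whether they differ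

The compounds shown leave open whether the lower number on the chlorinated core needs the nitrogen of the pyridin-4-yl group or would also come with a plain phenyl group on the same oxygen. They also leave open whether a small methyl group there, or fluoro in place of chloro, would give a similar number.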